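Two Ring Stereocentres Inverted, With Every Value a Limit

The source may hold more compounds than are shown below. What is called first, only, known or untested is meant among the compounds shown, and "the series" means these compounds.

Three compounds have so far been examined in a functional assay on A549 cells (Homo sapiens) for cytotoxicity, read by sulforhodamine B assay; a higher number here means a weaker inhibitor, a lower number a stronger inhibitor. Compound 1 `COc1cc([C@H]2Oc3c(OC)cc(CCCO)cc3[C@@H]2CO[C@@H]2O[C@H](CO)[C@@H](O)[C@H](O)[C@H]2O)ccc1O` gives > 10000 nM in this assay, which is a limit rather than a number. Compound 2 `COc1cc(C[C@H]2CO[C@@H](c3cc(OC)c(O)c(OC)c3)[C@H]2CO[C@@H]2O[C@@H](C)[C@H](O)[C@@H](O)[C@H]2O)cc(OC)c1O` gives > 10000 nM in this assay, again only a limit. Compound 3 `COc1cc(C[C@H](CO)[C@@H](CO[C@@H]2O[C@@H](C)[C@H](O)[C@@H](O)[C@H]2O)Cc2cc(OC)c(O)c(OC)c2)cc(OC)c1O` gives > 10000 nM in this assay, likewise a limit. Compound 2 therefore stands exactly where its two companions stand: the limit of > 10000 nM in this assay, at which 3 of the 3 values shown sit. Going by the values given here, no step between measured compounds can be drawn, since none of the three has a number.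

Compound 4 `COc1cc(C[C@@H]2CO[C@@H](c3cc(OC)c(O)c(OC)c3)[C@@H]2CO[C@@H]2O[C@@H](C)[C@H](O)[C@@H](O)[C@H]2O)cc(OC)c1O` has not yet been measured. It differs from compound 2 in this way: the two compounds have the same atoms and bonds and differ only in configuration as drawn: 2 of 8 stereo elements differ; a stereocentre at a saturated ring carbon is drawn R in compound 2 and S in compound 4; a stereocentre at a saturated ring carbon is drawn R in compound 2 and S in compound 4. The atoms and bonds are unchanged; only the drawn configuration at two saturated ring carbons is altered.

Among the compounds with values here, with every value so far a limit, the writer expects no step beyond the scatter in this assay, and estimates a step that the limit leaves unreadable from compound 2 to compound 4. Compound 4 is expected to give 15000 nM in this assay, within 8000 nM to 40000 nM, most probably reported once more only as a limit.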

Compound 4, half-maximal inhibitory concentration: > 10000 nM
Compound 4 gave a limit, no number (the forecaster's own chance of this, stated with the estimate: 85%); the middle value is on the limit's open side.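

No step can be read between compound 2 and compound 4, which differ only at two saturated ring carbons, because both values are limits: the limit of > 10000 nM in this assay, at which 4 of the 4 values shown sit. The compounds shown leave open whether that drawn configuration matters at all in this assay, and how strong any of the four compounds would be there.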